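Imidazole for pyrrolidine on the alkyne chain: two pairs

The source may hold more compounds than are shown below. What is called first, only, known or untested is meant among the compounds shown, and "the series" means these compounds.

Compound 1 `CN(C)C(=O)N(C)CC#CCN1CCCC1` and compound 2 `CN(C)C(=O)N(C)CC#CCn1ccnc1` share a core that is not the same as that of compound 3 `Cn1ccn(CC#CCN2CCCC2)c1=O` and compound 4 `Cn1ccn(CC#CCn2ccnc2)c1=O`; the difference between the two cores is not broken down here. In a functional assay on the whole organism for agonist activity, with Mus musculus as the target (on this read-out lower numbers stand for an effect already at smaller amounts and higher numbers for an effect only at larger amounts of compound), compound 1 gives 1.2 mg/kg, and compound 2 gives 11.8 mg/kg. The change between them is 1H-imidazol-1-yl in place of pyrrolidin-1-yl on a saturated chain carbon bound to a triple-bonded carbon, and it made a step of a 9.8-fold higher number from compound 1 to compound 2 (0.99 log units; beyond the scatter). In this assay compound 3 gives 3.7 mg/kg, which stands between the numbers of compound 1 and compound 2.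

Compound 4 has not been measured. It differs from compound 3 by 1H-imidazol-1-yl in place of pyrrolidin-1-yl on a saturated chain carbon bound to a triple-bonded carbon, which is the same change as that from compound 1 to compound 2, at the same place. Among the measured compounds shown here, only this one measured pair shows the change, so the expectation rests on it alone and on the number of compound 3. A step of the same direction and roughly the same size is expected from compound 3 to compound 4, namely an 8.1-fold higher number from compound 3 to compound 4 (0.91 log units; beyond the scatter), because the same change gave a 9.8-fold higher number from compound 1 to compound 2 (0.99 log units; beyond the scatter) and the value of compound 3 is 3.7 mg/kg. Compound 4 is therefore estimated at 30 mg/kg in this assay, with a likely range from 12 mg/kg to 90 mg/kg. Whether the second core carries the change with the same size is the open question the next measurement will answer.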

Compound 4, dose for half-maximal effect: 4.5 mg/kg
Compound 4: middle estimate off by 6.7-fold (0.82 log units), on the high side, and the stated range ends above it.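

On the core of compound 3, in this assay the exchange of pyrrolidin-1-yl for 1H-imidazol-1-yl gives a 1.2-fold higher number from compound 3 to compound 4 (0.09 log units; within the scatter) and so leaves no readable difference on this core. The size of the step does not carry over from one core to the other, since the two steps differ: the same change on two cores in this assay, a 9.8-fold higher number (0.99 log units; beyond the scatter) from compound 1 to compound 2 and a 1.2-fold higher number (0.09 log units; within the scatter) from compound 3 to compound 4, 8.1-fold (0.91 log units) apart, beyond the scatter of two such steps. A step read on the core of compound 1 therefore cannot be transferred as a number to the core of compound 3 in this series, but with one pair on each core this does not show which part of the two cores sets the size of the step, nor does it give a rule for any third core.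

Still open, going by these compounds, is whether the dependence on the core holds for other groups on a saturated chain carbon bound to a triple-bonded carbon, for instance an open-chain amine such as a dimethylamino group in place of pyrrolidin-1-yl, or a longer chain carrying either group. Also open, on these data alone, is which single feature of the cores matters, which only compounds differing from compound 1 or compound 3 in one place within the core could settle.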